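Amide aryl change from compound 1 to compound 4

The source may hold more compounds than are shown below. What is called first, only, known or untested is meant among the compounds shown, and "the series" means these compounds.

All numbers come from a functional assay on HT-29 cells (Homo sapiens) for cytotoxicity, read by MTT assay, with a stated time of 72 h; on this read-out lower numbers stand for stronger inhibition and higher numbers for weaker inhibition.
- compound 1, `O=C(CN1CCN(c2nnc(Cc3ccccc3)c3ccccc23)CC1)Nc1c(F)cccc1F`, gives 19700 nM in this assay
- compound 2, `O=C(CN1CCN(c2nnc(Cc3ccncc3)c3ccccc23)CC1)Nc1ccc(F)c(Cl)c1`, gives 880 nM in this assay
- compound 3, `O=C(CN1CCN(c2nnc(Cc3ccncc3)c3ccccc23)CC1)Nc1c(F)cccc1F`, gives 28700 nM in this assay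

Compound 1 holds the second highest of the three numbers. Its nearest neighbour is compound 3, with a 1.5-fold higher number from compound 1 to compound 3 (0.16 log units; within the scatter); its furthest is compound 2, whose value is far lower. Compound 4, `Cc1ccc(NC(=O)CN2CCN(c3nnc(Cc4ccccc4)c4ccccc34)CC2)c(C)c1`, differs from compound 1 by 2,4-dimethylphenyl in place of 2,6-difluorophenyl on an amide-type nitrogen. Among the compounds with values here, the one measured step on this same amide-type nitrogen is a 33-fold higher number from compound 2 to compound 3 (1.51 log units; beyond the scatter), a large worsening when 2,6-difluorophenyl enters. Leaving 2,6-difluorophenyl for a different aryl is therefore expected to give a lower number, though 2,4-dimethylphenyl is not 3-chloro-4-fluorophenyl, so a smaller gain than that step is expected, a 4.9-fold lower number from compound 1 to compound 4 (0.69 log units; beyond the scatter). Compound 4 is estimated at 4000 nM, in the range 900 nM to 18000 nM.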

Compound 4, half-maximal inhibitory concentration: "not active" (no number reported)
No number was reported for compound 4; there is nothing to compare the estimate with.
By their numbers in this assay, from the lowest: compound 2; then compounds 1 and 3 (each within the scatter of the next).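

Within the data shown here, compound 4 is reported only as "not active", without a number, so no step from compound 1 can be read. No measured evidence bears on this result. The compounds shown leave open how far 2,4-dimethylphenyl on the amide-type nitrogen separates compound 4 from compound 1.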